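Five-membered for six-membered amine ring in compound 3

The source may report more compounds than this note shows. Statements on the series, on what has been measured and on what is new or still open speak of the compounds shown alone.

Measured so far in a functional assay on HT-29 cells (Homo sapiens) for cytotoxicity, read by MTT assay, with a stated time of 72 h; on this read-out lower numbers stand for stronger inhibition and higher numbers for weaker inhibition:
compound 1 `COc1ccc(-c2cc(C(=O)Nc3ccc(Oc4ccnc5cc(OCCCN6CCCCC6)c(OC)cc45)c(F)c3)c3ccccc3n2)cc1` gives 690 nM
compound 2 `COc1ccc(-c2cc(C(=O)Nc3ccc(Oc4ccnc5cc(OCCCN6CCCCC6)c(OC)cc45)c(F)c3)c3cc(F)ccc3n2)cc1` gives 600 nM

For the measured compounds named here, compound 2 holds the smaller of the two numbers, but the only step recorded, a 1.2-fold lower number from compound 1 to compound 2 (0.06 log units; within the scatter), leaves compound 1 and compound 2 indistinguishable on this read-out. Both share the same amine-bearing side chain and differ only in the fluoro on the bicyclic ring of the amide acid part.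

Compound 3 `COc1ccc(-c2cc(C(=O)Nc3ccc(Oc4ccnc5cc(OCCCN6CCCC6)c(OC)cc45)c(F)c3)c3cc(F)ccc3n2)cc1` is the next candidate. It keeps the fluoro of compound 2 and changes the amine at the end of the side chain: pyrrolidin-1-yl in place of piperidin-1-yl on a saturated chain carbon, three bonds along the chain from an oxygen on an aromatic ring. Going by the values given here, no measured step touches this part of the molecule; the one step in hand, from compound 1 to compound 2, sits elsewhere and is itself within the scatter, so it gives no lead on direction. With the rest of the structure unchanged, the expectation for compound 3 in this assay is a step of about no change at the digits printed from compound 2 to compound 3 (within the scatter), that is, no shift beyond the scatter. Compound 3 is estimated at 600 nM, in the range 250 nM to 1500 nM.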

Compound 3, half-maximal inhibitory concentration: 610 nM
Beside the measured number, compound 3's estimate is 1.0-fold (0.01 log units) below it; the measured number falls inside the stated range.
By their numbers in this assay, from the lowest: compounds 2, 3 and 1 (each within the scatter of the next).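

In this assay, the step at the end of the side chain, a 1.0-fold higher number from compound 2 to compound 3 (0.01 log units; within the scatter), is within the scatter, so compound 2 and compound 3 cannot be told apart. The earlier compounds shown here both carried piperidin-1-yl and gave no reading on this position; this pair shows that, with the fluoro in place, a five-membered non-aromatic amine ring on the 3-carbon propyl chain reads the same as the six-membered one, at equal hydrogen-bond donor and acceptor counts. No measurement is at hand that bears on why the two amines read alike.

Open, going by these compounds, is whether a morpholine ring, an open-chain dimethylamino group or a longer chain such as 4-(pyrrolidin-1-yl)butyl would separate from compound 2 in this assay. Also open, on these data alone, is whether the swap from piperidin-1-yl to pyrrolidin-1-yl reads the same without the fluoro of compound 2, and whether this pair stays together on any read-out other than cytotoxicity in this one cell line.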